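Ether chain variants of the shared core

This account rests on a few compounds, and the source may have more. Where it says the series, first, only, none or still open, it means among the compounds named here.

Compound 1 `CCCCCOC1(c2ccc(Cl)cc2)SC=C(C)n2c1noc2=O` carries a pentyloxy chain on the shared core. In a functional assay on A2780/DX3 cells (Homo sapiens) for antiproliferative activity, read by MTT assay, with a stated time of 3 days (a higher number here means a weaker inhibitor, a lower number a stronger inhibitor), compound 1 gives only a limit, > 100000 nM. Compound 2 `CCCCCCCCCCCCCCCOC1(c2ccc(Cl)cc2)SC=C(C)n2c1noc2=O` adds decyl in place of hydrogen on a saturated chain carbon, five bonds along the chain from an oxygen on a saturated carbon. In this assay compound 2 likewise gives only a limit, > 100000 nM. The step that the two limits leave unreadable from compound 1 to compound 2 cannot be read because of the limit of > 100000 nM in this assay, at which 2 of the 2 values shown sit. Compound 3 `CC/C=C\COC1(c2ccc(Cl)cc2)SC=C(C)n2c1noc2=O` differs from compound 1 by but-1-en-1-yl in place of butyl on a saturated chain carbon bound to an oxygen on a saturated carbon. Within the data shown here, no measured step bears on this change in a readable way, as both values shown are limits. Compound 3 is therefore expected to stay at the limit as well, with the step of a number no higher from compound 1 to compound 3 (the limit leaves the size open) estimated as lying within the scatter. The estimate for compound 3 in this assay is 100000 nM, in the range 30000 nM to 300000 nM.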

Compound 3, half-maximal inhibitory concentration: 103000 nM
Estimate against measurement, compound 3: 1.0-fold (0.01 log units) below; the range from low to high includes it.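

The new value gives no readable step from compound 1 to compound 3, because compound 1 stands only at a limit: the limit of > 100000 nM in this assay, at which 2 of the 3 values shown sit.

In this assay the compounds shown leave open whether the pentyloxy and (pent-2-en-1-yl)oxy chains differ at all.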